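Swapping Chloride for Mesylate on the Side Chain

The source may hold more compounds than are shown below. What is called first, only, known or untested is meant among the compounds shown, and "the series" means these compounds.

Compound 2 `CS(=O)(=O)N1CC(CCl)c2cc(Br)c(OCc3ccccc3)cc21` shares its core with compound 1 `CS(=O)(=O)N1CC(CCl)c2cc(Br)c(O)cc21` and compound 3 `CS(=O)(=O)N1CC(CCl)c2cc(C=O)c(OCc3ccccc3)cc21`. In a functional assay on KB cells (Homo sapiens), read by crystal violet staining (on this read-out lower numbers stand for stronger inhibition and higher numbers for weaker inhibition), compound 2 gives 6.18 ug/mL, the largest of the three numbers, although both others lie within the scatter of it. Compound 1 gives 3.8 ug/mL and compound 3 gives 3.24 ug/mL. Each known step is small: a 1.6-fold higher number from compound 1 to compound 2 (0.21 log units; within the scatter), and a 1.9-fold lower number from compound 2 to compound 3 (0.28 log units; within the scatter). Both of these steps change a group on the aromatic ring.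

Compound 4 `CS(=O)(=O)OCC1CN(S(C)(=O)=O)c2cc(OCc3ccccc3)c(Br)cc21` differs from compound 2 somewhere else: (methylsulfonyl)oxy in place of chloro on a saturated chain carbon bound to a saturated ring carbon. Among the measured compounds shown here, no measured step touches this side chain, so the two known steps bear on it only loosely, and each of them stayed within the scatter. The step from compound 2 to compound 4 in this assay is therefore expected to be a 1.1-fold lower number from compound 2 to compound 4 (0.05 log units; within the scatter), nothing beyond the scatter. Compound 4 is estimated at 5.5 ug/mL, with a range from 2 ug/mL to 15 ug/mL.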

Compound 4, half-maximal inhibitory concentration: 5.21 ug/mL
Beside the measured number, compound 4's estimate is 1.1-fold (0.02 log units) above it, and the stated range covers the measured number.
By their numbers in this assay, from the lowest: compounds 3, 1, 4 and 2 (each within the scatter of the next).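

Among the compounds shown here, compound 4 is the only compound here that changes the side chain rather than a group on the aromatic ring, and in this assay this change gives a 1.2-fold lower number from compound 2 to compound 4 (0.07 log units; within the scatter). On a saturated chain carbon bound to a saturated ring carbon, (methylsulfonyl)oxy, with 5 heavy atoms and 3 hydrogen-bond acceptors, can therefore stand in place of chloro, a single chlorine atom, without moving the number beyond the scatter. No measurement on hand speaks to why the number holds.

Among the compounds shown, only these two groups sit at this place, so it remains open whether an amine or a longer chain there would shift the number beyond the scatter. From the compounds shown here alone, it is also open whether the same swap would read alike in compound 1 or compound 3.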